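A few compounds are considered here, and "the series" means these few. Any claim that something is new, unique, unknown or untested is made for them only; others in the source may bear on it.

The measured compounds:

Compound 1 `FC(F)(F)c1ccc(CSc2nc(N3CCCCC3)c3ccccc3n2)cc1` in a functional assay on MCF7 cells (Homo sapiens) for cytotoxicity, read by MTT assay, with a stated time of 72 h (a lower number here means a stronger inhibitor, a higher number a weaker inhibitor), gives only a limit, > 50000 nM.
Compound 2 `COc1ccc(Nc2nc(SCc3ccc(C(F)(F)F)cc3)nc3ccccc23)c(OC)c1` in this assay gives only a limit, > 50000 nM.

Compound 2 therefore stands at a limit of this assay rather than at a number. For the measured compounds named here, both values shown sit at that same limit (the limit of > 50000 nM in this assay, at which 2 of the 2 values shown sit), so the one measured step, a step that the two limits leave unreadable from compound 1 to compound 2, cannot be read in size or direction. Compound 3 `COc1ccc(Nc2nc(SCc3ccc(C(F)(F)F)cc3)nc3ccccc23)cc1OC` differs from compound 2 by 3,4-dimethoxyphenyl in place of 2,4-dimethoxyphenyl on a nitrogen on an aromatic ring, a rearrangement of the same atoms. No measured step bears on this change, and the only step shown is unreadable, so there is nothing to set a size against. The step that the limit leaves unreadable from compound 2 to compound 3 is thus expected to be small or none beyond the scatter, with compound 3 most likely remaining at the same limit. Compound 3 is estimated at 60000 nM, within a range from 15000 nM to 200000 nM.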

Compound 3, half-maximal inhibitory concentration: > 50000 nM
Compound 3 gave a limit, no number; the forecaster's own chance of this, stated with the estimate: 75%; the middle value is on the limit's open side.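

Compound 3 also gives only a limit, so no step among compound 1, compound 2 and compound 3 can be read in size or direction: the limit of > 50000 nM in this assay, at which 3 of the 3 values shown sit.

On these data alone, what stays open is whether any change to the shared core would give an actual number in this assay rather than a limit.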